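Swapping the Aryl Group on a Weakly Active Compound

The compounds below may be only part of what the source reports. "The series", "measured", "known", "first", "only" and "open" are said of these compounds alone.

Compound 1 `O=S(=O)(/C=C/c1ccc(Cl)cc1Cl)Cc1ccc(Nc2ncnc3ccccc23)cc1`: 4000 nM
Compound 2 `O=S(=O)(/C=C/c1ccc(O)cc1)Cc1ccc(Nc2ncnc3ccc(Br)cc23)cc1`: 32000 nM

In a functional assay on MCF7 cells (Homo sapiens) (on this read-out lower numbers stand for stronger inhibition of growth and higher numbers for weaker inhibition of growth), compound 2 at 32000 nM has the higher of the two numbers, and its gap to compound 1 lies beyond the scatter. Compound 3 `O=S(=O)(/C=C/c1ccc(Cl)cc1Cl)Cc1ccc(Nc2ncnc3ccc(Br)cc23)cc1` differs from compound 2 by 2,4-dichlorophenyl in place of 4-hydroxyphenyl on a double-bonded chain carbon bound to a double-bonded chain carbon, on a double-bonded chain carbon bound to a double-bonded chain carbon. Compound 1 also carries 2,4-dichlorophenyl and gives 4000 nM, so a move toward stronger growth inhibition is expected in this assay. The estimated step, a 5.3-fold lower number from compound 2 to compound 3 (0.73 log units; beyond the scatter), is expected to fall beyond the scatter. Compound 3 is estimated at 6000 nM, with an expected range of 2000 nM to 18000 nM.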

Compound 3, concentration for 50% growth inhibition: 4000 nM
Compound 3: middle estimate off by 1.5-fold (0.18 log units), on the high side; the measured number falls inside the stated range.
By their numbers in this assay, from the lowest: compounds 1 and 3 (each within the scatter of the next); then compound 2.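

With the bromo group kept in place, 2,4-dichlorophenyl in place of 4-hydroxyphenyl gives an 8.0-fold lower number from compound 2 to compound 3 (0.90 log units; beyond the scatter) in this assay, the first clean sign that the aryl group matters at this position. Bromo in place of hydrogen on an aromatic carbon gives no change at the digits printed from compound 1 to compound 3 (within the scatter) when 2,4-dichlorophenyl is present, so that change has no visible effect on this read-out. A plain phenyl group at this place would help show whether the step follows the arrival of the two chlorines or the departure of the hydroxy group. Nothing given here explains the step.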